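From Methoxyphenyl to Trimethylphenyl at the Weak End

This account rests on a few compounds, and the source may have more. Where it says the series, first, only, none or still open, it means among the compounds named here.

Of the compounds shown here, three have been measured in a functional assay on PC-3 cells (Homo sapiens) for inhibition, read by MTT assay, with a stated time of 48 h; a higher number here means a weaker inhibitor, a lower number a stronger inhibitor. Compound 1 `COc1ccc(/C=C2\SC(=O)N(CCNC(=O)Nc3c(C)n(C)n(-c4ccccc4)c3=O)C2=O)cc1` gives 13900 nM, compound 2 `COc1cc(/C=C2\SC(=O)N(CCNC(=O)Nc3c(C)n(C)n(-c4ccccc4)c3=O)C2=O)cc(OC)c1OC` gives 35400 nM, and compound 3 `COc1ccc(/C=C2\SC(=O)N(CC(=O)Nc3c(C)n(C)n(-c4ccccc4)c3=O)C2=O)cc1` gives 93700 nM. Compound 3 has the highest number of the three, which makes it the weakest inhibitor of this small set, and its gaps to both others lie beyond the scatter.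

Compound 4 `Cc1cc(C)c(/C=C2\SC(=O)N(CC(=O)Nc3c(C)n(C)n(-c4ccccc4)c3=O)C2=O)c(C)c1` keeps everything in compound 3 except one group, on a double-bonded chain carbon bound to a double-bonded ring carbon: 2,4,6-trimethylphenyl in place of 4-methoxyphenyl on a double-bonded chain carbon bound to a double-bonded ring carbon. Going by the values given here, only one measured step changes the group at this place, and it is modest: a 2.5-fold higher number from compound 1 to compound 2 (0.41 log units; beyond the scatter). That step is a rough guide only, since compound 1 and compound 2 carry a different chain from compound 3, and the group entering there is not the 2,4,6-trimethylphenyl of compound 4. The data therefore favour no direction, and a large change is not expected. The estimated change, a 1.2-fold lower number from compound 3 to compound 4 (0.07 log units; within the scatter), is expected to stay within the scatter. For compound 4 the expected value is 80000 nM, with an estimated range from 30000 nM to 200000 nM.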

Compound 4, half-maximal inhibitory concentration: 81600 nM
For compound 4 the middle estimate is 1.0-fold (0.01 log units) below the measured one; measured number inside the range.
By their numbers in this assay, from the lowest: compound 1; then compound 2; then compounds 4 and 3 (each within the scatter of the next).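

In this assay, going by these compounds alone, the place on a double-bonded chain carbon bound to a double-bonded ring carbon now has a step on the chain of compound 3 that stays within the scatter (a 1.1-fold lower number from compound 3 to compound 4 (0.06 log units; within the scatter)), while the only earlier step at this place, on a different chain and with a different entering group, lay beyond it (a 2.5-fold higher number from compound 1 to compound 2 (0.41 log units; beyond the scatter)). The new change replaces 4-methoxyphenyl, which counts one hydrogen-bond acceptor, with 2,4,6-trimethylphenyl, which is all carbon and counts none, so on this chain an aromatic group at this place can lose its oxygen with no readable shift in the number. Nothing measured here explains why this swap leaves the number where it is.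

Still open, from the compounds shown here alone, is whether 2,4,6-trimethylphenyl would behave the same way on the chain of compound 1, or 3,4,5-trimethoxyphenyl on the chain of compound 3. Also open, going by these compounds, is whether a phenyl ring carrying an amine or a carboxylic acid at this place would give a number beyond the scatter of compound 3.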